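The compounds below may be only part of what the source reports. "The series", "measured", "known", "first", "only" and "open" are said of these compounds alone.

Compound 3 `Cc1cn(C2CC(N=[N+]=[N-])C(COC(=O)OCCO)O2)c(=O)[nH]c1=O` is one of three carbonate esters built on a shared azido nucleoside core. In a functional assay on MT4 cells (Homo sapiens) for cytotoxicity (a higher number here means that more compound is tolerated, a lower number that less compound is tolerated), compound 3 gives > 50000 nM, which is a limit of the assay and not a number. Compound 1 `Cc1cn(C2CC(N=[N+]=[N-])C(COC(=O)OCCCCO)O2)c(=O)[nH]c1=O` gives > 50000 nM in this assay, again only a limit. Compound 2 `Cc1cn(C2CC(N=[N+]=[N-])C(COC(=O)OCCCN)O2)c(=O)[nH]c1=O` gives > 50000 nM, also a limit. The three results share (the limit of > 50000 nM in this assay, at which 3 of the 3 values shown sit), so no ordering among them can be drawn, and the step that the two limits leave unreadable from compound 1 to compound 2, the step that the two limits leave unreadable from compound 1 to compound 3 and the step that the two limits leave unreadable from compound 2 to compound 3 all remain unreadable. Compound 4 `Cc1cn(C2CC(N=[N+]=[N-])C(COC(=O)CCCN)O2)c(=O)[nH]c1=O` differs from compound 3 by 3-aminopropyl in place of 2-hydroxyethoxy on a carbonyl carbon, turning the carbonate into an ester. Among the measured compounds shown here, no measured step carries a readable size that bears on this change; the only guidance is that every compound so far tolerates the highest concentration tested. On that basis compound 4 is expected to behave in the same way, with the step of a number no higher from compound 3 to compound 4 (the limit leaves the size open) expected to show no change beyond the scatter. Compound 4 is therefore estimated at 50000 nM, with a range from 25000 nM to 100000 nM, and most likely reported again only as a limit.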

Compound 4, half-maximal cytotoxic concentration: > 50000 nM
Compound 4: only a limit was reported; the forecaster's own chance of this, stated with the estimate: 80%; the middle value sits exactly at the limit.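

In this assay compound 4 gives > 50000 nM, which is a limit and not a number. None of the steps from compound 1, compound 2 or compound 3 to compound 4 can be read, since all four compounds share one limit: the limit of > 50000 nM in this assay, at which 4 of the 4 values shown sit.

The compounds shown leave open whether their tolerated concentrations differ at all.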